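The source may hold more compounds than are shown below. What is called first, only, known or untested is meant among the compounds shown, and "the series" means these compounds.

Three compounds have been measured:
compound 1, `COc1ccc(/C=C/C(=O)c2ccc(OC)c3c2OC(C)(C)C=C3)cc1O`, giving 800 nM in a functional assay on A-375 cells (Homo sapiens) for cytotoxicity, read by MTT assay; on this read-out lower numbers stand for stronger inhibition and higher numbers for weaker inhibition;
compound 3, `CCC(=O)Oc1cc(/C=C/C(=O)c2ccc(OC)c3c2OC(C)(C)C=C3)ccc1OC`, giving 240 nM in this assay.
Compound 2, `C#CCOc1cc(/C=C/C(=O)c2ccc(OC)c3c2OC(C)(C)C=C3)ccc1OC`, sits at the limit of > 10000 nM in this assay, at which 1 of the 3 values shown sits, and gives no number; its reading is > 10000 nM.

Among the two numbers, compound 3 stands lowest. Its nearest neighbour is compound 1, and the step between them is a 3.3-fold lower number from compound 1 to compound 3 (0.52 log units; beyond the scatter), the change being propanoyl in place of hydrogen on an oxygen on an aromatic ring. The other steps, an at least 12-fold higher number from compound 1 to compound 2 (1.09 log units; beyond the scatter) and an at least 41-fold lower number from compound 2 to compound 3 (1.61 log units; beyond the scatter), also turn on what sits on that same oxygen.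

Compound 4, `COc1ccc(/C=C/C(=O)c2ccc(OC)c3c2OC(C)(C)C=C3)cc1OC(=O)CCl`, keeps the ester of compound 3 and differs only at its far end: chloro in place of methyl on a saturated chain carbon bound to a carbonyl carbon. Among the measured compounds shown here, none of the measured steps alters the acyl chain while keeping the ester, so they bear on this change only indirectly: they show that propanoyl on that oxygen gives the lowest number and propargyl a limit, and say nothing about exchanging methyl for chloro on a saturated chain carbon bound to a carbonyl carbon. With the ester itself unchanged, no step beyond the scatter is expected in this assay. The expected value for compound 4 is 300 nM, with a range from 120 nM to 800 nM, so the expected step is a 1.3-fold higher number from compound 3 to compound 4 (0.10 log units; within the scatter), small in either direction.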

Compound 4, half-maximal inhibitory concentration: 450 nM
Compound 4: middle estimate off by 1.5-fold (0.18 log units), on the low side, and the stated range covers the measured number.
By their numbers in this assay, from the lowest: compounds 3, 4 and 1 (each within the scatter of the next, the first and the last beyond it). At a limit, above all of these: compound 2.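

With the ester kept and only the far end of the acyl chain altered, chloro in place of methyl gives a 1.9-fold higher number from compound 3 to compound 4 (0.27 log units; within the scatter), so in this assay this end of the chain tolerates the exchange without a change that can be told from the scatter, while the same ester read against the free hydroxyl gives a 1.8-fold lower number from compound 1 to compound 4 (0.25 log units; within the scatter), unlike the step beyond the scatter seen with propanoyl, a 3.3-fold lower number from compound 1 to compound 3 (0.52 log units; beyond the scatter). Set against the propargyl ether on that oxygen, the chloro-bearing ester still shows a large step, an at least 22-fold lower number from compound 2 to compound 4 (1.34 log units; beyond the scatter), so both esters shown stand far from that ether. The reading for compound 2 is a limit of the assay and not a number: the limit of > 10000 nM in this assay, at which 1 of the 4 values shown sits.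

The compounds shown leave open how a longer acyl chain such as butanoyl, or an amine or a carboxylic acid at the far end of the chain, or a bromo or fluoro in place of the chloro, would read in this assay. With a single pair differing at this end of the chain, no trend along the chain can yet be stated.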